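A few compounds are considered here, and "the series" means these few. Any claim that something is new, unique, unknown or untested is made for them only; others in the source may bear on it.

Measured compounds in a functional assay on Jurkat cells (Homo sapiens) for inhibition; on this read-out lower numbers stand for stronger inhibition and higher numbers for weaker inhibition:
compound 1 `CC(C)[C@H](NC(=O)COc1cccc2ccccc12)C(=O)N[C@@H](CC(=O)O)C(=O)CSc1nc(-c2ccccc2)c(-c2ccccc2)[nH]1`: > 200000 nM.
compound 2 `CC(C)[C@H](NC(=O)COc1cccc2ccccc12)C(=O)N[C@@H](CC(=O)O)C(=O)CSc1nc(-c2ccccc2)c(-c2ccccc2)o1`: > 200000 nM.
compound 3 `Cc1nnc(SCC(=O)[C@H](CC(=O)O)NC(=O)[C@@H](NC(=O)COc2cccc3ccccc23)C(C)C)s1`: 190000 nM.

For compound 1 the entry is a limit of the assay, not a number. For compound 2 the entry is likewise a limit. Compound 3 is the only one of the three with a measured number; the other two sit at the limit of > 200000 nM in this assay, at which 2 of the 3 values shown sit. Within the data shown here, no step between measured compounds is available, so nothing here shows how far the group on the sulfur moves the read-out. Compound 4 `CC(C)[C@H](NC(=O)COc1cccc2ccccc12)C(=O)N[C@@H](CC(=O)O)C(=O)CSc1nccc(C(F)(F)F)n1` is to be measured next. It differs from compound 3 by 4-(trifluoromethyl)pyrimidin-2-yl in place of 5-methyl-1,3,4-thiadiazol-2-yl on a sulfur. With the series this weak, the expected step of a 1.1-fold lower number from compound 3 to compound 4 (0.05 log units; within the scatter) is none beyond the scatter, and a limit rather than a number is a real possibility. Compound 4 is estimated at 170000 nM, range 50000 nM to 200000 nM.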

Compound 4, half-maximal inhibitory concentration: > 200000 nM
Compound 4: only a limit was reported (the forecaster's own chance of this, stated with the estimate: 50%); middle value at least 1.1-fold (0.07 log units) away from the limit.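

In this assay compound 4 gives > 200000 nM, which is a limit and not a number. Putting 4-(trifluoromethyl)pyrimidin-2-yl in place of 5-methyl-1,3,4-thiadiazol-2-yl on the sulfur gives an at least 1.0-fold higher number from compound 3 to compound 4 (0.02 log units; that floor lies within the scatter), so this first step at the position has a floor but no readable size, and a six-membered ring there brings no number into the assay's range. The series remains largely at the assay's ceiling: the limit of > 200000 nM in this assay, at which 3 of the 4 values shown sit.

On these data alone, how far the true step extends past that floor stays open. Also open, as far as these compounds go, is whether a group such as an amine or a longer alkyl chain on the sulfur would give a number clearly lower than that of compound 3.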